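Shifting a fluorine on the amide aryl group

The source may report more compounds than this note shows. Statements on the series, on what has been measured and on what is new or still open speak of the compounds shown alone.

Measured compounds:
- compound 1 `Cc1ccccc1N(C)C(=O)c1ccc(-c2ccc(OS(N)(=O)=O)cc2)o1` gives 31 nM in an assay on T47D cells for inhibition of Steryl-sulfatase (Homo sapiens), read by HPLC, with a stated time of 24 h; a higher number here means a weaker inhibitor, a lower number a stronger inhibitor
- compound 2 `Cc1cccc(F)c1N(C)C(=O)c1ccc(-c2ccc(OS(N)(=O)=O)cc2)o1` gives "nd" (no result reported) in this assay
- compound 3 `Cc1ccc(F)cc1N(C)C(=O)c1ccc(-c2ccc(OS(N)(=O)=O)cc2)o1` gives "nd" (no result reported) in this assay

Compound 3 stands without a single number in this assay: no result was reported for it, and compound 2 is in the same position, so only compound 1 offers a numerical anchor for this series. Compound 4 `Cc1cc(F)ccc1N(C)C(=O)c1ccc(-c2ccc(OS(N)(=O)=O)cc2)o1` has not yet been measured. It differs from compound 3 by 4-fluoro-2-methylphenyl in place of 5-fluoro-2-methylphenyl on an amide-type nitrogen, with the same atoms joined differently. For the measured compounds named here, no step between measured compounds exists, so nothing is known about how moving the fluorine about this ring affects this assay. On that basis no step beyond the usual scatter is expected in either direction between compound 3 and compound 4, though the absence of a number for compound 3 leaves this open. Compound 4 is therefore estimated to land near the value of compound 1, at about 35 nM, with a range from 8 nM to 150 nM expected to cover most repeat measurements.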

Compound 4, half-maximal inhibitory concentration: 15 nM
Compound 4: middle estimate off by 2.3-fold (0.37 log units), on the high side; the range from low to high includes it.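

In this assay, for the compounds shown here, the 4-fluoro-2-methylphenyl group on the amide-type nitrogen supplies the first measured step: fluoro in place of hydrogen on an aromatic carbon gives a 2.1-fold lower number from compound 1 to compound 4 (0.32 log units; beyond the scatter), a modest move toward a stronger inhibitor that lies beyond the usual scatter. Going by these compounds alone, this shows that, with the rest of the structure unchanged, the aryl group of compound 1 can carry a fluorine at this one placement and lose no inhibitory strength, which the earlier compounds could not show without numbers of their own. Nothing available explains why this step occurs.

On these data alone, compound 2 and compound 3 have no reported result, so their steps to compound 1 and compound 4 cannot be read, and it remains open whether the lower number depends on where the fluorine sits on the ring. As far as these compounds go, it is also open whether a chloro, methoxy or nitrile group in place of the fluorine of compound 4 would give a similar number, or a different one, in this assay.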